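This account rests on a few compounds, and the source may have more. Where it says the series, first, only, none or still open, it means among the compounds named here.

In a functional assay on HT-29 cells (Homo sapiens) for antiproliferative activity, read by sulforhodamine B assay, with a stated time of 48 h (a lower number here means a stronger inhibitor, a higher number a weaker inhibitor), three compounds sharing one core have been measured. Compound 2 `CCCCc1ccc(NS(=O)(=O)c2ccc(N3CCNC3=O)cc2)cc1` gives 610 nM, the highest number of the three and beyond the usual scatter from the other two: compound 1 `CCc1ccccc1NS(=O)(=O)c1ccc(N2CCNC2=O)cc1` gives 240 nM, and compound 3 `Cc1ccc(NS(=O)(=O)c2ccc(N3CCNC3=O)cc2)cc1C` gives 230 nM. Compound 4 `CC(C)(C)c1ccc(NS(=O)(=O)c2ccc(N3CCNC3=O)cc2)cc1` has not been measured. It differs from compound 2 as follows: tert-butyl in place of butyl on an aromatic carbon. For the measured compounds named here, the only measured single-place step is a 1.0-fold lower number from compound 1 to compound 3 (0.02 log units; within the scatter), which lies within the scatter. It exchanges 3,4-dimethylphenyl and 2-ethylphenyl rather than butyl and tert-butyl, so it offers only weak guidance. No step beyond the scatter is therefore expected in this assay, with a slight lean towards a lower number. The expected change is a 1.5-fold lower number from compound 2 to compound 4 (0.18 log units; within the scatter). Compound 4 is estimated at 400 nM, with an expected range of 160 nM to 1000 nM.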

Compound 4, half-maximal inhibitory concentration: > 1000 nM
Compound 4: no number, only a limit (the forecaster's own chance of this, stated with the estimate: 2%); at least 2.5-fold (0.39 log units) between middle value and limit.
By their numbers in this assay, from the lowest: compounds 3 and 1 (each within the scatter of the next); then compound 2. At a limit, above all of these: compound 4.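

Putting tert-butyl in place of butyl keeps the same atoms and only joins them differently, yet in this assay there is an at least 1.6-fold higher number from compound 2 to compound 4 (0.21 log units; that floor lies within the scatter) at this aromatic carbon. Only a floor is known for this step, and that floor alone does not separate the two compounds, but nothing here shows tert-butyl giving a lower number than butyl. The reading for compound 4 is a limit of the assay, not a number: the limit of > 1000 nM in this assay, at which 1 of the 4 values shown sits.

Still open, on these data alone, is how an amine, a carboxylic acid or a longer chain such as hexyl would read on this aromatic carbon.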